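One Fluoro Fewer on the Difluorophenyl of Compound 2

The compounds below may be only part of what the source reports. "The series", "measured", "known", "first", "only" and "open" are said of these compounds alone.

Among the compounds with values here, compound 2 `CN(C(=O)NC(=O)c1c(F)cccc1F)c1nc(C(F)(F)F)c(C(=O)N/N=C/c2ccc(C(F)(F)F)cc2)s1` is the single compound with a numerical result in a functional assay on BCG823 cells (Homo sapiens) for inhibition, read by MTT assay, with a stated time of 72 h; a higher number here means a weaker inhibitor, a lower number a stronger inhibitor; in this assay compound 2 gives 34.9 ug/mL. Compound 1 `CN(C(=O)NC(=O)c1ccc(C(F)(F)F)cc1)c1nc(C(F)(F)F)c(C(=O)N/N=C/c2ccc(C(F)(F)F)cc2)s1` is reported in this assay as a limit, > 100 ug/mL. The step of an at least 2.8-fold lower number from compound 1 to compound 2 (0.45 log units; beyond the scatter) shows that the aryl group on the carbonyl carbon moves the result, though its true size is hidden by the limit of > 100 ug/mL in this assay, at which 1 of the 2 values shown sits. Compound 3 `CN(C(=O)NC(=O)c1ccccc1F)c1nc(C(F)(F)F)c(C(=O)N/N=C/c2ccc(C(F)(F)F)cc2)s1` differs from compound 2 by hydrogen in place of fluoro on an aromatic carbon. Within the data shown here, no measured step removes a single fluoro from this ring, so the change can only be judged as a smaller version of the aryl swap seen in an at least 2.8-fold lower number from compound 1 to compound 2 (0.45 log units; beyond the scatter). Compound 3 is therefore expected to stay close to compound 2, estimated at 50 ug/mL with a range of 20 ug/mL to 120 ug/mL. This expectation means a step of a 1.4-fold higher number from compound 2 to compound 3 (0.16 log units; within the scatter), likely within the scatter or modestly toward a higher number.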

Compound 3, half-maximal inhibitory concentration: 3.87 ug/mL
For compound 3 the middle estimate is 13-fold (1.11 log units) above the measured one; measured number outside the range, below it.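

In this assay, the step of a 9.0-fold lower number from compound 2 to compound 3 (0.96 log units; beyond the scatter) shows that a single hydrogen in place of fluoro on this aromatic carbon, ortho to a large group, moves the result by itself. On this one pair, the change from 2,6-difluorophenyl to 2-fluorophenyl goes toward the stronger inhibitor. The wider swap of aryl groups on the carbonyl carbon gives an at least 25-fold lower number from compound 1 to compound 3 (1.41 log units; beyond the scatter), and its true size stays hidden because of the limit: the limit of > 100 ug/mL in this assay, at which 1 of the 3 values shown sits.

The compounds shown leave open whether the remaining fluoro of the 2-fluorophenyl group matters at all, which a plain phenyl group would test. They also leave open whether a chlorine, a methyl or a methoxy group on that ring would give a number closer to compound 2 or to compound 3.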